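Weak Cytotoxic Series Extended by a Dimethoxy Change

This account rests on a few compounds, and the source may have more. Where it says the series, first, only, none or still open, it means among the compounds named here.

Compound 1 `COc1ccc(/C(=C\c2c[nH]c3ccc(OCc4ccccc4)cc23)C(=O)O)cc1`: in a functional assay on KB cells (Homo sapiens) for cytotoxicity, read by MTT assay, with a stated time of 72 h (on this read-out higher numbers stand for weaker inhibition and lower numbers for stronger inhibition), compound 1 gives 38500 nM.
Compound 2 `COc1ccc(Cn2cc(/C=C(/C(=O)O)c3ccccc3)c3cc(OCc4ccccc4)ccc32)cc1`: in this assay compound 2 gives 97000 nM.
Compound 3 `COc1ccccc1/C(=C\c1cn(C(C)=O)c2ccc(OCc3ccccc3)cc12)C(=O)O`: in this assay compound 3 reaches only a limit of the assay, > 100000 nM.

Of the compounds shown here, three of a shared core have been measured, and all of them sit at the weak end of the scale. Compound 3 stands apart in that its value is not a number at all but a limit; the evidence the limit of > 100000 nM in this assay, at which 1 of the 3 values shown sits, places it at the top edge of what the assay can report, so its true potency lies somewhere beyond that edge.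

The next compound, compound 4 `COc1cc(OC)cc(/C(=C\c2cn(C(C)=O)c3ccc(OCc4ccccc4)cc23)C(=O)O)c1`, keeps the whole core of compound 3 and alters one group: 3,5-dimethoxyphenyl in place of 2-methoxyphenyl on a double-bonded chain carbon bound to a carbonyl carbon and a double-bonded chain carbon. Going by the values given here, no step between measured compounds is available to guide the size of this change. With compound 3 at the limit, the expectation is that the step of an at least 1.1-fold lower number from compound 3 to compound 4 (0.04 log units; that floor lies within the scatter) stays within the scatter, so that compound 4 is also expected to be weak. The estimate for compound 4 is 90000 nM, with a range from 25000 nM to 300000 nM.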

Compound 4, half-maximal inhibitory concentration: 30400 nM
Estimate against measurement, compound 4: 3.0-fold (0.47 log units) above; low and high end bracket the measured number.
By their numbers in this assay, from the lowest: compounds 4 and 1 (each within the scatter of the next); then compound 2. At a limit, above all of these: compound 3.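

On the double-bonded chain carbon bound to a carbonyl carbon and a double-bonded chain carbon, the choice of aryl group can change the result: in this assay, 3,5-dimethoxyphenyl in place of 2-methoxyphenyl gives an at least 3.2-fold lower number from compound 3 to compound 4 (0.51 log units; beyond the scatter). Going by these compounds alone, this is the first step between two compounds differing in one place, and it shows that a change here can move the read-out beyond the usual scatter. Compound 3 has a limit rather than a true number, so the step gives only a minimum size: the limit of > 100000 nM in this assay, at which 1 of the 4 values shown sits.

The compounds shown cannot separate the effect of having two methoxy groups from the effect of where they sit, since both differ between the two groups. Going by these compounds, whether a hydroxyl group or an amine on this phenyl ring would lower the number further also remains open.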